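Moving from isopropylamino to 4-phenylpiperazin-1-yl

The source may hold more compounds than are shown below. What is called first, only, known or untested is meant among the compounds shown, and "the series" means these compounds.

Measured in a functional assay on the whole organism for antagonist activity, with Mus musculus as the target (a lower number here means that less compound is needed, a higher number that more compound is needed for the effect), so far:
Compound 1 `CC(C)NCC(=O)NCC(=O)N(C)c1ccc(Cl)cc1C(=O)c1ccccc1Cl` gives 1 mg/kg
Compound 2 `NCC(=O)NCC(=O)Nc1ccc([N+](=O)[O-])cc1C(=O)c1ccccc1Cl` gives 2.64 mg/kg
Compound 3 `CC(C)C(=O)NCC(=O)N(C)c1ccc(Cl)cc1C(=O)c1ccccc1Cl` gives 6 mg/kg

Compound 1 holds the lowest of the three numbers, with compound 2 nearest above it and compound 3 furthest. Compound 4 `CN(C(=O)CNC(=O)CN1CCN(c2ccccc2)CC1)c1ccc(Cl)cc1C(=O)c1ccccc1Cl` has not yet been measured in this assay and differs from compound 1 as follows: 4-phenylpiperazin-1-yl in place of isopropylamino on a saturated chain carbon bound to a carbonyl carbon with 4-phenylpiperazin-1-yl in place of isopropylamino on a saturated chain carbon bound to a carbonyl carbon. Within the data shown here, the only measured step that also removes the isopropylamino group is a 6.0-fold higher number from compound 1 to compound 3 (0.78 log units; beyond the scatter) and it is modest in size. Among the measured compounds shown here, no measured step swaps that group for another amine group, so this guide is a weak one. A step of similar modest size toward a higher number is expected. The expected step is a 4.0-fold higher number from compound 1 to compound 4 (0.60 log units; beyond the scatter) and it remains an estimate. For compound 4 the estimated value is 4 mg/kg with an expected span from 1 mg/kg to 15 mg/kg around it.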

Compound 4, dose for half-maximal effect: 75 mg/kg
The estimate for compound 4 lay 19-fold (1.27 log units) below the measured number, outside the stated range (above it).
By their numbers in this assay, from the lowest: compound 1; then compound 2; then compound 3; then compound 4.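

In this assay, the saturated chain carbon bound to a carbonyl carbon does not treat all amines alike: with 4-phenylpiperazin-1-yl in place of isopropylamino there is a 75-fold higher number from compound 1 to compound 4 (1.88 log units; beyond the scatter), a large step. Keeping an amine at this place therefore does not by itself keep the number low, since this step is larger than the modest 6.0-fold higher number from compound 1 to compound 3 (0.78 log units; beyond the scatter), where compound 3 carries no amine on that carbon. The change adds the rings and removes the hydrogen-bond donor of isopropylamino in one step, and no measurement at hand bears on the cause of the rise.

Open, as far as these compounds go, is whether the rise follows the phenyl ring or the piperazine ring, a question that 4-methylpiperazin-1-yl or piperidin-1-yl on the same carbon would address. Also open, from the compounds shown here alone, is whether a small amine such as dimethylamino, which has no hydrogen on its nitrogen, stays close to compound 1.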